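Bisarylidene series: imidazole to bromofuran swap at compound 2

A few compounds are considered here, and "the series" means these few. Any claim that something is new, unique, unknown or untested is made for them only; others in the source may bear on it.

Measured in a functional assay on NCI-H460 cells (Homo sapiens) for cytotoxicity, read by MTT assay, with a stated time of 72 h; a higher number here means a weaker inhibitor, a lower number a stronger inhibitor:
compound 1 `CC(C)(C)c1[nH]cnc1/C=c1\[nH]c(=O)/c(=C/c2cccc(C(=O)c3ccc(F)cc3)c2)[nH]c1=O`: 3.8 nM
compound 2 `Cc1[nH]cnc1/C=c1\[nH]c(=O)/c(=C/c2cccc(Oc3ccc(F)cc3)c2)[nH]c1=O`: 47.6 nM
compound 3 `Cc1[nH]cnc1/C=c1\[nH]c(=O)/c(=C/c2cccc(C(=O)c3ccc(F)cc3)c2)[nH]c1=O`: 15.9 nM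

Compound 2 gives the highest of the three numbers in this assay. The nearest number belongs to compound 3, 15.9 nM; the step of a 3.0-fold lower number from compound 2 to compound 3 (0.48 log units; beyond the scatter) is modest. The furthest belongs to compound 1, 3.8 nM.

Compound 4 `O=c1[nH]/c(=C\c2ccc(Br)o2)c(=O)[nH]/c1=C\c1cccc(Oc2ccc(F)cc2)c1` differs from compound 2 by 5-bromofuran-2-yl in place of 5-methyl-1H-imidazol-4-yl on a double-bonded chain carbon bound to an aromatic carbon. Among the measured compounds shown here, no measured step changes that group outright. The step of a 4.2-fold higher number from compound 1 to compound 3 (0.62 log units; beyond the scatter) shows the number responds modestly to a change on the group that leaves here, and a 3.0-fold lower number from compound 2 to compound 3 (0.48 log units; beyond the scatter) concerns the other chain. Because a 4.2-fold higher number from compound 1 to compound 3 (0.62 log units; beyond the scatter) already moves the number, replacing the whole group is expected to give a larger step, towards a higher number.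

For compound 4 the expected value is 150 nM, within 40 nM to 600 nM, an expected step of a 3.2-fold higher number from compound 2 to compound 4 (0.50 log units; beyond the scatter).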

Compound 4, half-maximal inhibitory concentration: 361 nM
Compound 4: middle estimate off by 2.4-fold (0.38 log units), on the low side; the measured number falls inside the stated range.
By their numbers in this assay, from the lowest: compound 1; then compound 3; then compound 2; then compound 4.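

In this assay, 5-bromofuran-2-yl in place of 5-methyl-1H-imidazol-4-yl gives a 7.6-fold higher number from compound 2 to compound 4 (0.88 log units; beyond the scatter) and, unlike the change on this group in the earlier step, exchanges the whole ring. The two groups match in heavy-atom count but differ in ring hetero atoms and hydrogen-bond donors, and these compounds cannot separate those differences. No measured evidence accounts for the step.

Still open, on these data alone, is whether the bromine or the furan ring carries the step, which a plain furan-2-yl group could address. Also open, as far as these compounds go, is whether the step holds with (4-fluorophenyl)carbonyl on the other chain.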